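Swapping the benzyl ring substituent in an MNK1 inhibitor series

The source may report more compounds than this note shows. Statements on the series, on what has been measured and on what is new or still open speak of the compounds shown alone.

Measured compounds and their numbers:
Compound 1 `O=c1ccc(-c2ccc3cn[nH]c3c2)cn1Cc1ccccc1`: 315 nM
Compound 2 `O=c1ccc(-c2ccc3cn[nH]c3c2)cn1Cc1cccc(Cl)c1`: 37 nM
Compound 3 `Nc1n[nH]c2cc(-c3ccc(=O)n(Cc4ccccc4)c3)ccc12`: 79 nM

In an assay for inhibition of MAP kinase-interacting serine/threonine-protein kinase 1 (Homo sapiens), read by luminescence and ADP-Glo, with a stated time of 2 h (a higher number here means a weaker inhibitor, a lower number a stronger inhibitor), compound 1 gives 315 nM, the highest of the three numbers, so it is the weakest inhibitor in this small set. Two single changes to compound 1 have been measured. Adding a chloro group on the benzyl ring gives compound 2, and an 8.5-fold lower number from compound 1 to compound 2 (0.93 log units; beyond the scatter). Adding an amino group on the shared core gives compound 3, and a 4.0-fold lower number from compound 1 to compound 3 (0.60 log units; beyond the scatter).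

Compound 4 `O=c1ccc(-c2ccc3cn[nH]c3c2)cn1Cc1ccc(C(F)(F)F)cc1` has not yet been measured in this assay. It differs from compound 1 in one place: trifluoromethyl in place of hydrogen on an aromatic carbon. Within the data shown here, no measured step places a group at this position of the benzyl ring, so the nearest guide is compound 2, where a halogen on the same ring produced an 8.5-fold lower number from compound 1 to compound 2 (0.93 log units; beyond the scatter). On that basis a modest lowering of the number is expected for compound 4, though with wide uncertainty because the position of the new group is different. The estimate for compound 4 is 160 nM, within a range of 40 nM to 640 nM, meaning an expected 2.0-fold lower number from compound 1 to compound 4 (0.29 log units; within the scatter).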

Compound 4, half-maximal inhibitory concentration: 1170 nM
Compound 4: the middle estimate sits 7.3-fold (0.86 log units) below what was measured, outside the stated range (above it).
By their numbers in this assay, from the lowest: compound 2; then compound 3; then compound 1; then compound 4.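

Adding a group to the benzyl ring does not always lower the number: in this assay, trifluoromethyl on an aromatic carbon para to a large group gives a 3.7-fold higher number from compound 1 to compound 4 (0.57 log units; beyond the scatter), the only single change in this set that makes the inhibitor weaker. The chloro change on the same ring goes the other way, with an 8.5-fold lower number from compound 1 to compound 2 (0.93 log units; beyond the scatter), so the one earlier result on this ring does not carry over to this group at this place. The chloro and trifluoromethyl compounds differ in both the group and its place on the ring, and no measurement shown here accounts for the rise in the number.

On these data alone, it remains open whether a chloro group at this same place would lower or raise the number, and whether trifluoromethyl elsewhere on the ring would act as it does here. The compounds shown also leave open how a smaller group such as fluoro or methyl, an amine or a carboxylic acid would fare at this place, and whether the amino group of compound 3 would change the outcome.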